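Adding a Methoxypropyl Chain to Compound 2

A few compounds are considered here, and "the series" means these few. Any claim that something is new, unique, unknown or untested is made for them only; others in the source may bear on it.

Compound 1 `CCCCN1CCCN(c2nc3ccccc3n2CCOCC)CC1`: 8.4 nM
Compound 2 `CN1CCN(c2nc3ccccc3[nH]2)CC1`: > 3000 nM
Compound 3 `CCCCN1CCN(c2nc3ccccc3n2CCOCC)CC1`: 15 nM

These three compounds have been tested in a functional assay on ileum for inhibition of histamine H1 receptor (Cavia porcellus); on this read-out higher numbers stand for weaker inhibition and lower numbers for stronger inhibition. Compound 1 gives 8.4 nM and compound 3 gives 15 nM; the two values lie within the usual scatter of each other. For compound 2 the assay reports only a limit, > 3000 nM, not a number. Compound 2 thus stands at the limit of > 3000 nM in this assay, at which 1 of the 3 values shown sits, the far end of the range seen so far.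

Compound 4 `COCCCn1c(N2CCN(C)CC2)nc2ccccc21` differs from compound 2 in one place: 3-methoxypropyl in place of hydrogen on an aromatic nitrogen. Going by the values given here, no step between measured compounds is available. Still, compound 1 at 8.4 nM and compound 3 at 15 nM both carry a chain on that aromatic nitrogen, so stronger inhibition is expected; the expected step is an at least 10-fold lower number from compound 2 to compound 4 (1.00 log units; beyond the scatter). Compound 4 is estimated at 300 nM, between 50 nM and 2000 nM.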

Compound 4, half-maximal inhibitory concentration: 860 nM
Compound 4: the middle estimate sits 2.9-fold (0.46 log units) below what was measured; the measured number falls inside the stated range.
By their numbers in this assay, from the lowest: compounds 1 and 3 (each within the scatter of the next); then compound 4. At a limit, above all of these: compound 2.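

In this assay, a single change, 3-methoxypropyl in place of hydrogen on the aromatic nitrogen, gives an at least 3.4-fold lower number from compound 2 to compound 4 (0.54 log units; beyond the scatter). Going by these compounds alone, this is the first direct evidence that a chain at this position strengthens inhibition. The earlier compounds shown here offered no comparison differing in one place only. Compound 2 gives only a limit, so the true step could be larger: the limit of > 3000 nM in this assay, at which 1 of the 4 values shown sits.

The compounds shown leave open how much of the step depends on the chain's oxygen or its length. A plain pentyl chain, or a chain ending in an amine, at the same position would address this.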